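The compounds below may be only part of what the source reports. "The series", "measured", "known", "first", "only" and "open" are said of these compounds alone.

Measured compounds:
Compound 1, `CNC(=O)CCn1nc(-c2ccccc2)ccc1=O`, 3.5%
Compound 2, `N=C(S)CCCCCn1nc(-c2ccccc2)ccc1=O`, 91.4%
Compound 3, `CCOC(=O)CCn1nc(-c2ccccc2)ccc1=O`, 6.3%

The read-out in a functional assay on the whole organism (stomach) for inhibition, with Rattus norvegicus as the target, at a dose of 100 mg/kg by the intraduodenal route (a higher number here means more inhibition at the dose given (going by the name of the read-out), a lower number less inhibition), separates these three compounds sharply. Compound 3 is the second highest of the three numbers, but its nearest neighbour is compound 1, and the gap a number 2.8 percentage points higher from compound 1 to compound 3 (within the scatter) lies within the scatter, so the two are not distinguished. The only large movements are a number 87.9 percentage points higher from compound 1 to compound 2 (beyond the scatter) and a number 85.1 percentage points lower from compound 2 to compound 3 (beyond the scatter), both arising where a group of 6 heavy atoms (4 carbon, 1 nitrogen, 1 sulfur; no ring) sits on the saturated chain carbon two bonds along the chain from an aromatic nitrogen.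

Compound 4, `N=C(S)CCCCn1nc(-c2ccccc2)ccc1=O`, is not yet measured in this assay. It differs from compound 3 by a group of 5 heavy atoms (3 carbon, 1 nitrogen, 1 sulfur; no ring) in place of a group of 5 heavy atoms (3 carbon, 2 oxygen; no ring), on a saturated chain carbon, two bonds along the chain from an aromatic nitrogen. The entering group resembles the group present in compound 2 in its kind of atoms, though it is one heavy atom shorter. Among the compounds with values here, the steps that bear on this change are a number 85.1 percentage points lower from compound 2 to compound 3 (beyond the scatter) and a number 87.9 percentage points higher from compound 1 to compound 2 (beyond the scatter), and both were large. A large rise in this assay is therefore expected for compound 4, of about a number 68.7 percentage points higher from compound 3 to compound 4 (beyond the scatter). Compound 4 is estimated at 75%, within a range from 45% to 95%.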

Compound 4, a percentage reported as inhibition, in the whole organism at one dose (the size of the read-out at that dose, not a potency): 33.8%
Compound 4: the middle estimate sits 41.2 percentage points above what was measured; the whole stated range lies above it.
By their numbers in this assay, from the lowest: compounds 1 and 3 (each within the scatter of the next); then compound 4; then compound 2.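

In this assay, the entering group brings only a partial gain at this place, with a number 27.5 percentage points higher from compound 3 to compound 4 (beyond the scatter) when it replaces ethoxycarbonyl and a number 30.3 percentage points higher from compound 1 to compound 4 (beyond the scatter) against the methylamide of compound 1. The length of the chain carrying this end group also counts, as the shorter chain gives a number 57.6 percentage points lower from compound 2 to compound 4 (beyond the scatter) at a saturated chain carbon, four bonds along the chain from an aromatic nitrogen, so the kind of atoms alone does not set the level reached by compound 2. Nothing available explains why either change has the size it has.

The compounds shown leave open whether a still longer chain with the same end group would go further or fall back. They also leave open whether a carboxylic acid or an amine at the chain end would behave like the ester and amide or like the sulfur-bearing group.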